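The compounds below may be only part of what the source reports. "The series", "measured", "known", "first", "only" and "open" are said of these compounds alone.

Compound 3 `Cc1nc(Nc2cccc(Cl)c2)sc1C(=O)/C=C/c1ccc(Cl)cc1` was tested in a functional assay on PC-3 cells (Homo sapiens) for cytotoxicity, read by MTT assay; on this read-out lower numbers stand for stronger inhibition and higher numbers for weaker inhibition. In this assay compound 3 gives only a limit, > 25000 nM. Two related compounds set the scale: compound 1 `COc1cccc(/C=C/C(=O)c2sc(Nc3cccc(C)c3)nc2C)c1` and compound 2 `Cc1cccc(Nc2nc(C)c(C(=O)/C=C/c3ccccc3Cl)s2)c1`. In this assay compound 1 likewise gives only a limit, > 25000 nM. Compound 2 gives 22200 nM in this assay. The values shown therefore cluster around (the limit of > 25000 nM in this assay, at which 2 of the 3 values shown sit). Compound 4 `Cc1cccc(Nc2nc(C)c(C(=O)/C=C/c3ccc(Cl)cc3)s2)c1` is not yet measured; it differs from compound 3 by methyl in place of chloro on an aromatic carbon. Within the data shown here, the only measured step, an at least 1.1-fold lower number from compound 1 to compound 2 (0.05 log units; that floor lies within the scatter), changes the other ring and lies within the scatter, so it does not bear on this change. Among the measured compounds shown here, with no step touching this part of the structure, the expected step of a number no higher from compound 3 to compound 4 (the limit leaves the size open) is none beyond the scatter. Compound 4 is therefore estimated at 25000 nM, with a range from 10000 nM to 60000 nM.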

Compound 4, half-maximal inhibitory concentration: > 25000 nM
Compound 4 was reported as a limit; the forecaster's own chance of this, stated with the estimate: 60%; the middle value lies on the limit itself.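

In this assay, among these compounds, 3-methylphenyl in place of 3-chlorophenyl on the amino group leaves compound 4 at a limit, as compound 3 was, so this step cannot be read, and neither can the one that links compound 1 with compound 4. Among the compounds shown here, the one readable step, with 4-chlorophenyl in place of 2-chlorophenyl on the chain, is an at least 1.1-fold higher number from compound 2 to compound 4 (0.05 log units; that floor lies within the scatter). At this position, methyl and chloro alike leave the compound at the limit shared by most of the set: the limit of > 25000 nM in this assay, at which 3 of the 4 values shown sit.

Any difference between methyl and chloro here stays hidden behind that limit. On these data alone, whether an amine or a carboxylic acid at this position would give a measurable value remains open.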